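A phenyl swap with no number to start from

The source may hold more compounds than are shown below. What is called first, only, known or untested is meant among the compounds shown, and "the series" means these compounds.

In a functional assay on NCI-H1993 cells (Homo sapiens) for inhibition, read by CCK-8 assay, with a stated time of 72 h (a lower number here means a stronger inhibitor, a higher number a weaker inhibitor), compound 1 (`Cn1cc(-c2cnc3nc(O)n(Cc4ccc5ncccc5c4)c3n2)cn1`) gives > 10000 nM as a limit of the assay, not a number. Compound 2 (`CCC(c1ccc2ncccc2c1F)n1cnc2ncc(-c3cnn(CCO)c3)nc21`) has the entry "not determined" (no result reported) and so offers no result to compare. Compound 3 (`CCC(c1ccc2ncccc2c1F)n1cnc2ncc(-c3ccccc3)nc21`) has the entry "not determined" (no result reported) too, so it has no place on the scale of this assay yet. The compound waiting to be tested is compound 4 (`CCC(c1ccc2ncccc2c1F)n1cnc2ncc(-c3ccc(C(N)=O)c(F)c3)nc21`). The change 4-carbamoyl-3-fluorophenyl in place of phenyl on an aromatic carbon puts 4-carbamoyl-3-fluorophenyl in place of phenyl on an aromatic carbon. With no starting number, the step cannot be sized exactly, but a large one towards stronger inhibition is expected. The estimated value for compound 4 is 40 nM and the expected range runs from 5 nM to 400 nM at its upper end.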

Compound 4, half-maximal inhibitory concentration: 665 nM
For compound 4 the middle estimate is 17-fold (1.22 log units) below the measured one, outside the stated range (above it).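

The entries shown for compound 2 and compound 3 give no number to set beside compound 4, so no step to compound 4 can be read. As far as these compounds go, whether 4-carbamoyl-3-fluorophenyl gives stronger or weaker inhibition than phenyl stays open.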